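The source may report more compounds than this note shows. Statements on the series, on what has been measured and on what is new or still open speak of the compounds shown alone.

Measured compounds:
compound 1, `Cc1cc(/C=C/C#N)cc(C)c1Oc1cc(NCCN2CCN(C)CC2)nc(Nc2ccc(C#N)cc2)c1`, 7960 nM
compound 2, `Cc1cc(/C=C/C#N)cc(C)c1Oc1cc(NCCN(C)C)nc(Nc2ccc(C#N)cc2)n1`, 3040 nM

In an ADME assay on MT4 cells (Homo sapiens) for cytotoxicity, read by MTT assay, with a stated time of 5 days (on this read-out higher numbers stand for lower toxicity in this test and lower numbers for higher toxicity in this test), compound 2 gives 3040 nM, the lower of the two numbers here, and compound 1 gives 7960 nM; the gap between them lies beyond the scatter of repeated measurements. Among the compounds with values here, no step between these two measured compounds is given, because the two structures differ in more than one place, so only their two values can be set side by side.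

Compound 3, `Cc1cc(/C=C/C#N)cc(C)c1Oc1cc(NC2CC2)nc(Nc2ccc(C#N)cc2)n1`, has not yet been measured in this assay. Compared with compound 2 the change is cyclopropyl in place of 2-(dimethylamino)ethyl on a nitrogen on an aromatic ring. Within the data shown here, nothing among the measured compounds follows this same change, so the direction of the step in this assay can only be guessed. The account expects a step of modest size from compound 2 to compound 3, a 1.6-fold higher number from compound 2 to compound 3 (0.22 log units; within the scatter), toward a somewhat higher number in this assay, though a result within the scatter would not surprise. Compound 3 is thus estimated at 5000 nM, with a range from 1500 nM to 16000 nM.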

Compound 3, half-maximal cytotoxic concentration: 3000 nM
Beside the measured number, compound 3's estimate is 1.7-fold (0.22 log units) above it; low and high end bracket the measured number.
By their numbers in this assay, from the lowest: compounds 3 and 2 (each within the scatter of the next); then compound 1.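

In this assay, within the data shown here, the exchange of 2-(dimethylamino)ethyl for cyclopropyl on a nitrogen on an aromatic ring gives a 1.0-fold lower number from compound 2 to compound 3 (0.01 log units; within the scatter), so this pair offers the first direct reading at this position, and the two compounds cannot be told apart on this read-out. The group that leaves has 5 heavy atoms, no ring and a hydrogen-bond acceptor, while the group that enters has 3 heavy atoms, a three-membered ring of carbon only and no hydrogen-bond acceptor, so in this pair a number of this size does not depend on the nitrogen of the chain. No measurement here gives a reason for this close agreement.

The compounds shown leave open whether this position stays as insensitive with other groups, such as a longer chain, a carboxylic acid or a morpholine ring at the end of the chain. They also leave open how much of the gap to compound 1 belongs to its 4-methylpiperazine-bearing chain and how much to the other place in which its core differs.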